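The source may hold more compounds than are shown below. What is called first, only, known or untested is meant among the compounds shown, and "the series" means these compounds.

Working notes on the series. Going by the values given here, in a functional assay on MDA-MB-231 cells (Homo sapiens) for antiproliferative activity, read by WST assay, with a stated time of 72 h (on this read-out higher numbers stand for weaker inhibition of growth and lower numbers for stronger inhibition of growth), compound 1 `N=C(N)c1ccc(/N=N/Nc2cccc(C#Cc3ccccn3)c2)cc1` gives 14400 nM and compound 2 `COc1ccc(C#Cc2cccc(N/N=N/c3ccc(C(=N)N)cc3)c2)cc1` gives 5500 nM, so compound 2 holds the lower of the two numbers so far. Compound 3 `N=C(N)c1ccc(/N=N/Nc2cccc(C#Cc3ccccc3)c2)cc1` is not yet measured. It differs from compound 2 as follows: hydrogen in place of methoxy on an aromatic carbon. In words, this is hydrogen in place of methoxy on an aromatic carbon, or 4-methoxyphenyl to phenyl. Among the compounds with values here, only one measured step bears on this change: a 2.6-fold lower number from compound 1 to compound 2 (0.42 log units; beyond the scatter), a modest step that exchanges the group on the same triple-bonded carbon. Within the data shown here, no measured pair shows the removal of methoxy alone, so the evidence is thin. A small step in this assay is expected, leaning to a higher number and staying within the scatter. The expected step is a 1.5-fold higher number from compound 2 to compound 3 (0.16 log units; within the scatter). For compound 3 the estimated value is 8000 nM, with an expected range from 3500 nM to 18000 nM.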

Compound 3, concentration for 50% growth inhibition: 9500 nM
The estimate for compound 3 lay 1.2-fold (0.07 log units) below the measured number, and the stated range covers the measured number.
By their numbers in this assay, from the lowest: compounds 2, 3 and 1 (each within the scatter of the next, the first and the last beyond it).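

In this assay, removing methoxy alone gives a 1.7-fold higher number from compound 2 to compound 3 (0.24 log units; within the scatter), and the neighbouring exchange of pyridin-2-yl for phenyl on the triple-bonded carbon gives a 1.5-fold lower number from compound 1 to compound 3 (0.18 log units; within the scatter). Neither single move from compound 3 leaves the scatter, so the wider gap, a 2.6-fold lower number from compound 1 to compound 2 (0.42 log units; beyond the scatter), appears only across the full exchange of pyridin-2-yl for 4-methoxyphenyl, with compound 3 unresolved from either end. Nothing available gives a reason for these numbers.

As far as these compounds go, whether another group on this aromatic carbon, such as ethoxy, an amine or a carboxylic acid, would separate from compound 3 beyond the scatter remains open. Also open is whether methoxy matters only on this ring position, since the compounds shown carry it at a single place.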